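Side-chain extension on compound 2 in the tail flick series

The compounds below may be only part of what the source reports. "The series", "measured", "known", "first", "only" and "open" are said of these compounds alone.

Going by the values given here, compound 2 `O=C(CN(c1nc(Cl)nc2[nH]cnc12)C1CC1)NCC(=O)OCc1ccccc1` and compound 1 `NC(=O)CC[C@H](NC(=O)CN(c1ncnc2c1ncn2C1CCCCO1)C1CC1)C(=O)OCc1ccccc1` are the two members with numbers so far. In a functional assay on the whole organism (Tail, strain ICR) with Mus musculus as the target, in the tail flick test, with a stated time of 60 min, at a dose of 25 umol/kg by the oral route (on this read-out higher numbers stand for a stronger effect at the one dose given and lower numbers for a weaker effect), compound 2 gives 41.9%, and compound 1 gives 39.4%. Compound 2 stands highest of the two numbers, but its gap to compound 1 lies within the scatter, so the two read as alike and no order between them can be claimed. Among the compounds with values here, no step between compounds that differ in one place is available from this pair.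

Compound 3 `N=C(N)NCCC[C@H](NC(=O)CN(c1nc(Cl)nc2[nH]cnc12)C1CC1)C(=O)OCc1ccccc1` is the next member to be measured in this assay. It differs from compound 2 in one place: a group of 7 heavy atoms (4 carbon, 3 nitrogen; no ring) in place of a hydrogen atom, on a saturated chain carbon bound to an amide-type nitrogen and a carbonyl carbon. Nothing in the measured pair shows how such a change bears on the read-out; the two values at hand only show two close numbers.

Within the data shown here, with no measured step of this kind to lean on, a modest step from compound 2 to compound 3 is expected, not far beyond the scatter in either direction, a number 3.1 percentage points higher from compound 2 to compound 3 (within the scatter). Compound 3 is expected to give 45% in this assay, with a range from 20% to 70%.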

Compound 3, a percentage reported as activity, at one dose (the size of the read-out at that dose, not a potency): 30.6%
For compound 3 the middle estimate is 14.4 percentage points above the measured one, within the range that was stated.
By their numbers in this assay, from the lowest: compounds 3, 1 and 2 (each within the scatter of the next, the first and the last beyond it).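

In this assay, replacing a hydrogen atom with the group of 7 heavy atoms, on a saturated chain carbon bound to an amide-type nitrogen and a carbonyl carbon, gives a number 11.3 percentage points lower from compound 2 to compound 3 (beyond the scatter). Going by these compounds alone, this is the first one-place step, and it shows that the read-out responds to a change at this carbon, with the direction of the step being downward for this group. The effect is not abolished at the one dose given, since compound 3 still gives 30.6%, but no measurement available on these compounds accounts for the step.

With a single group at this carbon, the compounds shown cannot separate the effect of this particular chain from that of any substituent placed there. A methyl group, a longer or shorter chain ending in an amine, or a chain ending in a carboxylic acid at the same carbon would show whether the step follows chain size or the group that the chain carries.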